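Adding a second chloro to compound 2

This account rests on a few compounds, and the source may have more. Where it says the series, first, only, none or still open, it means among the compounds named here.

Among three compounds that share a core and have been measured in a functional assay on PC-3 cells (Homo sapiens) for inhibition, read by sulforhodamine B assay, with a stated time of 48 h, tested at 100 uM (on this read-out higher numbers stand for more inhibition of growth at the one concentration tested and lower numbers for less inhibition of growth), compound 2, with the structure `O=c1c(C2N=C(c3ccccc3)SS2)coc2cc(Cl)ccc12`, stands highest: in this assay compound 2 gives 81%. Its nearest neighbour is compound 1, `O=c1c(C(=S)Nc2ccccc2)coc2ccccc12`, which in this assay gives 63%, a gap that lies beyond the scatter. Furthest away is compound 3, `O=c1c(C(=S)Nc2ccccc2)coc2cc(Cl)c(Cl)cc12`, which in this assay gives 16%; compound 3 carries two chloro groups, and its number is far lower than that of compound 1, which carries none.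

Compound 4, `O=c1c(C2N=C(c3ccccc3)SS2)coc2cc(Cl)c(Cl)cc12`, is not yet measured. It differs from compound 2 in one place: chloro in place of hydrogen on an aromatic carbon. The change sits on an aromatic carbon of a six-membered aromatic ring of carbon only, part of a fused system of two rings, ortho to a chloro group.

Within the data shown here, no measured pair shows this exact step, so the expectation rests on the two thioamide compounds, where compound 3, with two chloro groups, gives 16% and compound 1, with none, gives 63%. On that basis a decrease is expected from compound 2 to compound 4, of about a number 36 percentage points lower from compound 2 to compound 4 (beyond the scatter). Compound 4 is therefore estimated to give 45% in this assay, within a range from 20% to 75%.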

Compound 4, percent growth inhibition at one concentration: 70%
Beside the measured number, compound 4's estimate is 25 percentage points below it; measured number inside the range.
By their numbers in this assay, from the lowest: compound 3; then compounds 1 and 4 (each within the scatter of the next); then compound 2.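

In this assay, among these compounds, the single change of chloro in place of hydrogen on this aromatic carbon, ortho to a chloro group, gives a number 11 percentage points lower from compound 2 to compound 4 (beyond the scatter) as a modest step, and this is the first direct reading of what a second chloro does here. The loss is partial: with both chloro groups in place, compound 4 still gives 70% of growth inhibition, so this position accepts the extra chlorine without the number collapsing. Compound 3, which also carries two chloro groups but has a different group on the shared core, gives 16% in the same test, so the printed values show that two chloro groups do not by themselves fix a low number.

From the compounds shown here alone, it remains open whether a different group on this same carbon, such as fluoro, methoxy or an amine, would give a number closer to that of compound 2, and whether the step would keep its size at concentrations other than the single one tested. Nothing in the data at hand explains why the step has this size.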